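Trimming the Piperazine Substituent Down to a Methyl

The source may hold more compounds than are shown below. What is called first, only, known or untested is meant among the compounds shown, and "the series" means these compounds.

Compound 2 `CCCn1c(=O)[nH]c2nc(-c3ccc(S(=O)(=O)N4CCN(Cc5cccc(C)c5)CC4)cc3)[nH]c2c1=O` is one of three compounds tested in an assay on CHO cells for displacement of a labelled ligand from adenosine receptor A3 (Homo sapiens), read by scintillation counting, with a stated time of 45 min, in the presence of a further agent that is not named here; a lower number here means a stronger inhibitor, a higher number a weaker inhibitor. In this assay compound 2 gives > 1000 nM, which is a limit of the assay rather than a number. Compound 1 `CCCn1c(=O)[nH]c2nc(-c3ccc(S(=O)(=O)N4CCN(c5ccc(F)cc5)CC4)cc3)[nH]c2c1=O` likewise gives > 1000 nM, also a limit. Compound 3 `CCCn1c(=O)[nH]c2nc(-c3ccc(S(=O)(=O)N(C)C)cc3)[nH]c2c1=O` gives 1220 nM. Going by the values given here, the only measured step, a step that the two limits leave unreadable from compound 1 to compound 2, is unreadable, as both of its ends rest on (the limit of > 1000 nM in this assay, at which 2 of the 3 values shown sit). Compound 4 `CCCn1c(=O)[nH]c2nc(-c3ccc(S(=O)(=O)N4CCN(C)CC4)cc3)[nH]c2c1=O` differs from compound 2 by hydrogen in place of 3-methylphenyl on a saturated chain carbon bound to an amine nitrogen in a ring. Compound 3, which carries no ring at all on its sulfonamide nitrogen, gives 1220 nM. On that basis the step that the limit leaves unreadable from compound 2 to compound 4 is expected to stay within the scatter. Compound 4 is thus expected to give 2000 nM, within a range from 700 nM to 8000 nM, with a limit the likely report.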

Compound 4, inhibition constant: > 1000 nM
Compound 4 gave a limit, no number; the forecaster's own chance of this, stated with the estimate: 70%; the middle value lies beyond the limit too.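

Compound 4 gives a limit, not a number, so its steps to compound 1, compound 2 and compound 3 cannot be read: the limit of > 1000 nM in this assay, at which 3 of the 4 values shown sit.

From the compounds shown here alone, whether methyl, 3-methylbenzyl and 4-fluorophenyl differ at all in this assay stays open.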